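A Second Methoxy Group on a Weak Growth Inhibitor

The source may report more compounds than this note shows. Statements on the series, on what has been measured and on what is new or still open speak of the compounds shown alone.

Three compounds have been measured in a functional assay on HT-29 cells (Homo sapiens) for inhibition, read by sulforhodamine B assay, with a stated time of 48 h; on this read-out lower numbers stand for stronger inhibition of growth and higher numbers for weaker inhibition of growth:

Compound 1 `O=C1C=COC(/C=C/c2ccc(C(F)(F)F)cc2)C1`: 33.3 uM
Compound 2 `O=c1ccoc(/C=C/c2ccccc2)c1`: 344 uM
Compound 3 `COc1ccc(/C=C/c2cc(=O)cco2)cc1`: 379 uM

Compound 3 has the highest of these three numbers. Compound 2 lies within the scatter of it, so the two cannot be told apart, while compound 1 gives a clearly lower number, beyond the scatter. Compound 4 `COc1ccc(/C=C/c2cc(=O)cco2)cc1OC` differs from compound 3 by methoxy in place of hydrogen on an aromatic carbon. Going by the values given here, the only measured step of this kind, a 1.1-fold higher number from compound 2 to compound 3 (0.04 log units; within the scatter), stayed within the scatter. A second methoxy group is therefore expected to leave the number essentially unchanged, with no step beyond the scatter in either direction. For compound 4 the expected step is a 1.0-fold higher number from compound 3 to compound 4 (0.00 log units; within the scatter). Compound 4 is estimated at 380 uM, within a range from 190 uM to 760 uM.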

Compound 4, concentration for growth inhibition (reported as GI): 807 uM
Estimate against measurement, compound 4: 2.1-fold (0.33 log units) below; measured number above the stated range.
By their numbers in this assay, from the lowest: compound 1; then compounds 2 and 3 (each within the scatter of the next); then compound 4.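

In this assay methoxy in place of hydrogen, ortho to a methoxy group, gives a 2.1-fold higher number from compound 3 to compound 4 (0.33 log units; beyond the scatter) and so a modest weakening of growth inhibition. The same kind of change earlier gave a 1.1-fold higher number from compound 2 to compound 3 (0.04 log units; within the scatter) and showed no measurable shift, so the outcome of adding a methoxy group differs between these two places. No measurement available here explains that difference.

Still open, as far as these compounds go, is whether an amine or a carboxylic acid at this position would lower the number or raise it. Also open, from the compounds shown here alone, is whether this methoxy group would give the same step without its methoxy neighbour.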